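This account rests on a few compounds, and the source may have more. Where it says the series, first, only, none or still open, it means among the compounds named here.

Compound 1 `CC/C(=C(/c1ccc(/C=C/C(=O)O)cc1)c1cc2ccccc2[nH]1)c1ccccc1C#N`: 9 nM
Compound 2 `CC/C(=C(/c1ccc(/C=C/C(=O)O)cc1)c1cc2ccccc2[nH]1)c1cccc(OC(F)(F)F)c1`: 282 nM
Compound 3 `CC/C(=C(/c1ccc(/C=C/C(=O)O)cc1)c1cc2ccccc2[nH]1)c1ccc(F)cc1Cl`: 39 nM

In a functional assay on MCF7 cells (Homo sapiens) for inhibition (a higher number here means a weaker inhibitor, a lower number a stronger inhibitor), compound 3 stands second highest of the three numbers, nearest to compound 1 and furthest from compound 2. Compound 4 `CC/C(=C(/c1ccc(/C=C/C(=O)O)cc1)c1cc2ccccc2[nH]1)c1c(C)cccc1Cl` is not yet measured; it differs from compound 3 by 2-chloro-6-methylphenyl in place of 2-chloro-4-fluorophenyl on a double-bonded chain carbon bound to a double-bonded chain carbon and a saturated chain carbon. Going by the values given here, the steps that bear on this are the two aryl exchanges at the same place: a 4.3-fold higher number from compound 1 to compound 3 (0.64 log units; beyond the scatter) and a 7.2-fold lower number from compound 2 to compound 3 (0.86 log units; beyond the scatter), both beyond the scatter yet modest. The move from compound 3 to compound 4 keeps the chlorine and is expected to give a step of a 1.3-fold higher number from compound 3 to compound 4 (0.11 log units; within the scatter) of comparably modest size, direction uncertain. For compound 4 the expected value in this assay is 50 nM, range 15 nM to 200 nM.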

Compound 4, half-maximal inhibitory concentration: 30 nM
Beside the measured number, compound 4's estimate is 1.7-fold (0.22 log units) above it; measured number inside the range.
By their numbers in this assay, from the lowest: compound 1; then compounds 4 and 3 (each within the scatter of the next); then compound 2.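

In this assay 2-chloro-6-methylphenyl in place of 2-chloro-4-fluorophenyl gives a 1.3-fold lower number from compound 3 to compound 4 (0.11 log units; within the scatter) and so shows that this place on the double-bonded chain carbon accepts a methyl in a chlorine-bearing phenyl without a change beyond the scatter. The new group also stands apart from both other aryl groups, with a 9.4-fold lower number from compound 2 to compound 4 (0.97 log units; beyond the scatter) on one side and a 3.3-fold higher number from compound 1 to compound 4 (0.52 log units; beyond the scatter) on the other, so 2-cyanophenyl stays ahead of both chlorine-bearing groups. As far as these compounds go, whether a 2-methoxyphenyl or 2-aminophenyl group here would match compound 1 remains open. Nothing measured here gives a reason for these differences.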